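From pentamethylphenyl to 2,6-dibromophenyl on the shared core

A few compounds are considered here, and "the series" means these few. Any claim that something is new, unique, unknown or untested is made for them only; others in the source may bear on it.

In a physicochemical assay for permeability, using PAMPA (a lower number here means that the compound crosses the layer more slowly, a higher number that the compound crosses the layer faster), compound 1 `Cc1oc(-c2c(C)c(C)c(C)c(C)c2C)nc1CN1CCC(C(=O)NCCCN2C[C@H](C)C[C@H](C)C2)CC1` gives 455 10^-6 cm/s. Within the data shown here, its only numerical neighbour is compound 2 `Cc1ccccc1-c1nc(CN2CCC(C(=O)NCCCN3CCC(C(C)C)CC3)CC2)c(C)o1` at 396 10^-6 cm/s, and the two numbers lie within the scatter of each other. For compound 3 `Cc1ccccc1-c1nc(CN2CCC(C(=O)NCCCN3CCCC(C(C)C)C3)CC2)c(C)o1` the entry reads "not determined" (no result reported), so it offers no comparison.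

Compound 4 `Cc1oc(-c2c(Br)cccc2Br)nc1CN1CCC(C(=O)NCCCN2C[C@H](C)C[C@H](C)C2)CC1` departs from compound 1 in one place: 2,6-dibromophenyl in place of 2,3,4,5,6-pentamethylphenyl on an aromatic carbon. This puts 2,6-dibromophenyl in place of 2,3,4,5,6-pentamethylphenyl on an aromatic carbon, while the rest of the structure stays the same.

Among the measured compounds shown here, no measured pair differs in one place only, so this change has no direct precedent. For the measured compounds named here, compound 1 at 455 10^-6 cm/s and compound 2 at 396 10^-6 cm/s differ in more than one place, yet their values remain within the scatter, and this is the only guide available. The step of a 1.3-fold lower number from compound 1 to compound 4 (0.13 log units; within the scatter) in this assay is expected to be small and downward, without clearly leaving the scatter. Compound 4 is estimated at 340 10^-6 cm/s, with an expected range from 170 10^-6 cm/s to 600 10^-6 cm/s.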

Compound 4, apparent permeability: < 1 10^-6 cm/s
Compound 4 was reported as a limit; the forecaster's own chance of this, stated with the estimate: 3%; middle value at least 340-fold (2.53 log units) from the limit.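

In this assay, the group on this aromatic carbon of the shared core is not a silent position: 2,6-dibromophenyl in place of 2,3,4,5,6-pentamethylphenyl gives an at least 450-fold lower number from compound 1 to compound 4 (2.65 log units; beyond the scatter), the only single-place step shown and one that lies well outside anything the earlier values suggested. Compound 4 is reported as a limit, < 1 10^-6 cm/s. The step therefore sets a minimum for the change and does not give its full size, because the reading for compound 4 is not a number: the limit of < 1 10^-6 cm/s in this assay, at which 1 of the 4 values shown sits.

The compounds shown do not separate the arrival of the two bromine atoms from the loss of the five methyl groups. Going by these compounds, how 2,6-dimethylphenyl or 2,6-dichlorophenyl on this position would read in this assay stays open, and with it where between the two extremes the change takes hold.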